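The compounds below may be only part of what the source reports. "The series", "measured", "known", "first", "only" and "open" are said of these compounds alone.

Three compounds have so far been tested in an assay on isolated protein for inhibition of DNA topoisomerase 1 (Homo sapiens), with a stated time of 30 min, tested at 20 uM; a higher number here means a stronger effect of the compound at the concentration tested, a lower number a weaker effect:

compound 1 `Cc1ccc2nc(-c3ccccc3C(F)(F)F)[nH]c(=O)c2c1` gives 21.1%
compound 2 `CCN(CC)c1ccc2nc(-c3ccccc3N(C)C)[nH]c(=O)c2c1` gives 0%
compound 3 `Cc1ccc2nc(-c3ccccc3N(C)C)[nH]c(=O)c2c1` gives 21.1%

Compound 3 stands level with compound 1 at the digits shown, and these two together hold the highest numbers of the three. Compound 2 lies furthest from compound 3, the gap being a number 21.1 percentage points higher from compound 2 to compound 3 (beyond the scatter). Compound 4 `Cc1ccc2nc(-c3ccccc3OC(F)(F)F)[nH]c(=O)c2c1` is the next compound to be tested. It differs from compound 3 in one place: trifluoromethoxy in place of dimethylamino on an aromatic carbon. Going by the values given here, only one measured step concerns the same group on compound 3, namely no change at the digits printed from compound 1 to compound 3 (within the scatter), where trifluoromethyl and dimethylamino gave the same reading within the scatter. Nothing measured here shows what trifluoromethoxy itself does on this core, so the range must stay wide. The expectation is therefore that the step of a number 1.1 percentage points lower from compound 3 to compound 4 (within the scatter) stays within the scatter in this assay, with no clear direction. Compound 4 is thus expected to give 20%, between 5% and 35%.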

Compound 4, a percentage reported as inhibition, at one concentration (the size of the read-out at that concentration, not a potency): 0%
Compound 4: middle estimate off by 20 percentage points, on the high side; the measured number lies below the stated range.
By their numbers in this assay, from the lowest: compounds 2 and 4 (each within the scatter of the next); then compounds 1 and 3 (each within the scatter of the next).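

In this assay, replacing dimethylamino with trifluoromethoxy gives a number 21.1 percentage points lower from compound 3 to compound 4 (beyond the scatter), and replacing trifluoromethyl with trifluoromethoxy gives a number 21.1 percentage points lower from compound 1 to compound 4 (beyond the scatter). The earlier comparison of the two other groups showed no change at the digits printed from compound 1 to compound 3 (within the scatter), which made this position look open to a change of group, but the new steps show that this does not extend to every group placed here. Nothing available explains why trifluoromethoxy stands apart from the other two groups.

From the compounds shown here alone, it remains open whether a smaller group on the same carbon, such as methoxy, a single fluorine or a chlorine, would read like trifluoromethoxy or like dimethylamino. Going by these compounds, it is also open how a hydroxyl group or a longer alkoxy chain would behave at this position on the shared core.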